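The source may report more compounds than this note shows. Statements on the series, on what has been measured and on what is new or still open speak of the compounds shown alone.

The measured compounds and their numbers in a functional assay on DLD-1 cells (Homo sapiens) for inhibition, read by MTT assay, with a stated time of 72 h; on this read-out higher numbers stand for weaker inhibition and lower numbers for stronger inhibition:

compound 1, `CNCc1c(OC)cc(Oc2cccc(Nc3ccccc3)c2)cc1OC`, gives 11900 nM
compound 2, `COc1cc(Oc2cccc(Nc3ccccc3)c2)cc(OC)c1CN[C@H](C)c1ccccc1`, gives 8570 nM
compound 3, `COc1cc(Oc2cccc(Nc3ccccc3)c2)cc(OC)c1CNCc1ccc(Cl)cc1`, gives 3740 nM

Compound 3 stands lowest of the three numbers, and both of its steps from the others lie beyond the scatter: a 3.2-fold lower number from compound 1 to compound 3 (0.50 log units; beyond the scatter) and a 2.3-fold lower number from compound 2 to compound 3 (0.36 log units; beyond the scatter). The remaining pair is closer, a 1.4-fold lower number from compound 1 to compound 2 (0.14 log units; within the scatter), and shows no difference worth reading.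

Compound 4, `COc1ccc(CCCNCc2c(OC)cc(Oc3cccc(Nc4ccccc4)c3)cc2OC)cc1`, differs from compound 3 in one place: 2-(4-methoxyphenyl)ethyl in place of 4-chlorophenyl on a saturated chain carbon bound to an amine nitrogen. Among the compounds with values here, two measured steps bear on this position. The step of a 3.2-fold lower number from compound 1 to compound 3 (0.50 log units; beyond the scatter) shows that putting an aromatic ring on this chain carbon lowers the number modestly, and the step of a 2.3-fold lower number from compound 2 to compound 3 (0.36 log units; beyond the scatter) shows that the 4-chlorobenzyl arrangement does modestly better than 1-phenylethyl. Within the data shown here, compound 4 keeps an aromatic ring on the chain but moves it further out and replaces the chlorine by a methoxy group, a change for which none of the measured steps is a direct precedent. The expectation is therefore a small step, most likely towards a somewhat higher number, a 1.3-fold higher number from compound 3 to compound 4 (0.13 log units; within the scatter). Compound 4 is estimated at 5000 nM in this assay, with a range from 2000 nM to 15000 nM.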

Compound 4, half-maximal inhibitory concentration: 2540 nM
For compound 4 the middle estimate is 2.0-fold (0.29 log units) above the measured one, and the stated range covers the measured number.
By their numbers in this assay, from the lowest: compounds 4 and 3 (each within the scatter of the next); then compounds 2 and 1 (each within the scatter of the next).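

In this assay, 3-(4-methoxyphenyl)propyl in place of 4-chlorobenzyl on the amine nitrogen gives no difference worth reading, with a 1.5-fold lower number from compound 3 to compound 4 (0.17 log units; within the scatter), so this position accepts both groups alike on this read-out. The earlier compounds shown here set only the 4-chlorobenzyl group apart from methyl and 1-phenylethyl, whereas the new group also stands apart from both, with a 3.4-fold lower number from compound 2 to compound 4 (0.53 log units; beyond the scatter) and a 4.7-fold lower number from compound 1 to compound 4 (0.67 log units; beyond the scatter), which shows that the lower numbers are not tied to a chlorine-bearing group. Nothing given here explains why the two groups read alike at this position.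

Chain and ring substituent differ together between compound 3 and compound 4, so their separate contributions remain open, and a 4-methoxybenzyl or a 3-(4-chlorophenyl)propyl group on the amine nitrogen would tell them apart. Also open, from the compounds shown here alone, is whether the aromatic ring is needed at all, which a cyclohexyl ring in its place or a chain ending in a carboxylic acid would test.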